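Methoxy in Place of Hydrogen: Compound 1 to Compound 3

This account rests on a few compounds, and the source may have more. Where it says the series, first, only, none or still open, it means among the compounds named here.

Compound 1: `O=c1sn(-c2ccccc2)c(=O)n1Cc1ccccc1` — 2380 nM
Compound 2: `O=c1sn(-c2ccc(F)cc2)c(=O)n1-c1ccccc1` — < 2000 nM

Two compounds sharing the same core have been examined in an ADME assay, in phosphate buffer, with a stated time of 30 min, tested at 1 mM, at a dose of 1 mM; a higher number here means more compound in the circulation at the dose given, a lower number less compound in the circulation. In this assay compound 1 gives 2380 nM. Compound 2 is reported only as < 2000 nM, which is a limit of the assay rather than a number. Going by the values given here, compound 1 therefore carries the only full number in the set, the other entry being (the limit of < 2000 nM in this assay, at which 1 of the 2 values shown sits). Among the compounds with values here, no two measured compounds differ from each other in a single place, so no step between measured compounds can be read off, and the reading for compound 1 stands on its own.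

Compound 3, `COc1ccc(-n2sc(=O)n(Cc3ccccc3)c2=O)cc1`, differs from compound 1 by methoxy in place of hydrogen on an aromatic carbon. Nothing measured here tells how this assay responds to such a change, so the expected step is taken as none beyond the usual scatter, in either direction. Compound 3 is accordingly expected to give about 2000 nM, estimated to fall between 900 nM and 4500 nM. The step this estimate implies is expected to be a 1.2-fold lower number from compound 1 to compound 3 (0.08 log units; within the scatter).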

Compound 3, maximal plasma concentration: 5490 nM
The estimate for compound 3 lay 2.7-fold (0.44 log units) below the measured number; measured number outside the range, above it.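

Going by these compounds alone, with compound 3, this assay gains its only comparison between two compounds that differ in one place: methoxy in place of hydrogen on an aromatic carbon of a six-membered aromatic ring of carbon only, para to a large group, gives a 2.3-fold higher number from compound 1 to compound 3 (0.36 log units; beyond the scatter). This shows that the read-out is not indifferent to a change at this position, and that here the addition of methoxy moves it toward more compound in the circulation while the rest of compound 1 stays the same. The finding rests on this single pair and on this one group, and nothing shown here accounts for the step.

From the compounds shown here alone, it remains open whether the higher number belongs to methoxy itself or would also follow from another group at this position, such as an ethoxy, an amine or a carboxylic acid. Going by these compounds, it is also open whether methoxy would give a step of similar size on a different carbon of the same ring, or on the other aromatic ring of compound 1.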